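Compound 3: a dichlorophenyl swap at the assay limit

The source may report more compounds than this note shows. Statements on the series, on what has been measured and on what is new or still open speak of the compounds shown alone.

In a functional assay on ECV-304 cells (Homo sapiens) for cytotoxicity (a higher number here means a weaker inhibitor, a lower number a stronger inhibitor), compound 1 `COc1ccc(S(=O)(=O)NN2C(=S)S/C(=C\c3ccc(Cl)c(Cl)c3)C2O)cc1` gives > 50000 nM as a limit of the assay and not a number. Compound 2 `Cc1cccc(/C=C2\SC(=S)N(NS(=O)(=O)c3ccccc3)C2=O)c1` gives > 50000 nM and this too is a limit, so compound 2 has no numeric standing in the series. The data so far amount to the limit of > 50000 nM in this assay, at which 2 of the 2 values shown sit, and nothing more.

Within the data shown here, the next compound is compound 3 `O=C1/C(=C/c2ccc(Cl)c(Cl)c2)SC(=S)N1NS(=O)(=O)c1ccccc1`, which carries 3,4-dichlorophenyl in place of 3-methylphenyl on a double-bonded chain carbon bound to a double-bonded ring carbon as its only change from compound 2. Among the measured compounds shown here, no step between measured compounds is available to size this change. Compound 1 bears the 3,4-dichlorophenyl group and gives > 50000 nM as a limit, so no change beyond the scatter is expected in this assay. The expected step is a number no higher from compound 2 to compound 3 (the limit leaves the size open) with no set direction. Another report as a limit is the likeliest outcome. Compound 3 is estimated at 50000 nM with an expected range from 20000 nM to 100000 nM in this reading.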

Compound 3, half-maximal inhibitory concentration: > 50000 nM
Compound 3: only a limit was reported (the forecaster's own chance of this, stated with the estimate: 75%); the middle value sits exactly at the limit.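

In this assay compound 3 gives > 50000 nM, a limit of the assay and not a number. Compound 2 gives > 50000 nM, also a limit, so no step can be read between compound 2 and compound 3. The compounds shown leave open whether 3,4-dichlorophenyl in place of 3-methylphenyl changes the value at all, and whether any compound in the series gives a numeric value in this assay.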